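From 2-nitrophenoxy to benzyl on the shared core

The source may hold more compounds than are shown below. What is called first, only, known or untested is meant among the compounds shown, and "the series" means these compounds.

Compound 1 `CC(C)(Oc1ccccc1F)C1OCC(C/C=C\CCC(=O)O)C(c2cccnc2)O1` gives 166 nM in a functional assay for inhibition, with Homo sapiens as the target; on this read-out higher numbers stand for weaker binding and lower numbers for tighter binding
Compound 2 `CC(C)(Oc1ccccc1[N+](=O)[O-])C1OCC(C/C=C\CCC(=O)O)C(c2cccnc2)O1` gives 11.2 nM in this assay

Within the data shown here, compound 2 holds the lower of the two numbers so far (11.2 nM), which in this assay stands for the tighter binding. Compound 3 `CC(C)(Cc1ccccc1)C1OCC(C/C=C\CCC(=O)O)C(c2cccnc2)O1` keeps the shared core and differs from compound 2 in one place: benzyl in place of 2-nitrophenoxy on a saturated chain carbon bound to two saturated chain carbons and a saturated ring carbon.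

Among the measured compounds shown here, only one measured step bears on this change, and only in part. It is a 15-fold lower number from compound 1 to compound 2 (1.17 log units; beyond the scatter), a large step beyond the scatter, with nitro in place of fluoro on an aromatic carbon. For the measured compounds named here, no measured step replaces the whole 2-nitrophenoxy group. Compound 3 carries no nitro, and compound 1, also without nitro, gives 166 nM here. A step of similar size towards a higher number is therefore expected in this assay, though with wide uncertainty. The expected step is a 16-fold higher number from compound 2 to compound 3 (1.21 log units; beyond the scatter) (an estimate). For compound 3 the estimated value is 180 nM (range 40 nM to 800 nM).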

Compound 3, dissociation constant: 513 nM
Estimate against measurement, compound 3: 2.9-fold (0.45 log units) below, and the stated range covers the measured number.
By their numbers in this assay, from the lowest: compound 2; then compound 1; then compound 3.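

Taking the whole 2-nitrophenoxy group away and putting benzyl in its place on the saturated chain carbon gives, in this assay, a 46-fold higher number from compound 2 to compound 3 (1.66 log units; beyond the scatter), so this position responds to more than the change on the aromatic ring that the first two compounds compared. The same replacement starting from 2-fluorophenoxy gives a 3.1-fold higher number from compound 1 to compound 3 (0.49 log units; beyond the scatter), a smaller step but still beyond the scatter, and so compound 3, with its benzyl group, has the highest number of the three, above both compounds that carry a substituted phenoxy group. Nothing measured here speaks to the reason for either step.

Benzyl differs from the two phenoxy groups both in lacking a ring substituent and in having a carbon rather than an oxygen joined to the aromatic ring, so the compounds shown do not separate these two differences. As far as these compounds go, it remains open how an unsubstituted phenoxy group, a 2-nitrobenzyl group or a 2-aminophenoxy group would compare at this position in this assay.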